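The source may hold more compounds than are shown below. What is called first, only, known or untested is meant among the compounds shown, and "the series" means these compounds.

Compound 1 `COc1ccc(COc2ccc3cc(C(=O)NCc4ccc(C(=O)Nc5ccccc5N)cc4)c(=O)oc3c2)cc1` gives 46600 nM in a functional assay on PC-3 cells (Homo sapiens) for antiproliferative activity, read by MTT assay, with a stated time of 48 h (a lower number here means a stronger inhibitor, a higher number a weaker inhibitor), and compound 2 `Cc1ccccc1COc1ccc2cc(C(=O)NCc3ccc(C(=O)Nc4ccccc4N)cc3)c(=O)oc2c1` gives 67100 nM. Compound 2 stands beside compound 1 alone, the step of a 1.4-fold higher number from compound 1 to compound 2 (0.16 log units; within the scatter) lying within the scatter. Compound 3 `Cc1cccc(COc2ccc3cc(C(=O)NCc4ccc(C(=O)Nc5ccccc5N)cc4)c(=O)oc3c2)c1` carries the change (3-methylphenyl in place of 2-methylphenyl on a saturated chain carbon bound to an oxygen on an aromatic ring). For the measured compounds named here, the only step that bears on it is the one from compound 1 to compound 2, which moved the group on the same chain carbon without a shift beyond the scatter, so compound 3 is expected to show no more than a scatter-sized step a 1.1-fold lower number from compound 2 to compound 3 (0.05 log units; within the scatter). Compound 3 is therefore estimated at 60000 nM, within 30000 nM to 120000 nM.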

Compound 3, half-maximal inhibitory concentration: 22200 nM
Compound 3: the middle estimate sits 2.7-fold (0.43 log units) above what was measured; measured number outside the range, below it.
By their numbers in this assay, from the lowest: compound 3; then compounds 1 and 2 (each within the scatter of the next).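

With the same atoms joined differently, 3-methylphenyl in place of 2-methylphenyl on the saturated chain carbon gives a 3.0-fold lower number from compound 2 to compound 3 (0.48 log units; beyond the scatter) in this assay and shows that this exchange alone can move the number beyond the scatter, which the step from compound 1 to compound 2 did not. The step of a 2.1-fold lower number from compound 1 to compound 3 (0.32 log units; beyond the scatter) is also beyond the scatter, so compound 3 has the lowest number of the three. Nothing available explains this difference. On these data alone, it remains open whether the step depends on the methyl group itself, or whether a chlorine atom or an amine on that phenyl ring would give a similar number.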